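A few compounds are considered here, and "the series" means these few. Any claim that something is new, unique, unknown or untested is made for them only; others in the source may bear on it.

Compound 1, `N[C@]1(C(=O)O)[C@H]2[C@@H](C[C@H]1OCCCc1ccccc1)[C@]2(F)C(=O)O`, is an ether of the shared core; in an assay on CHO cells for binding affinity to metabotropic glutamate receptor 2 (Rattus norvegicus) (a lower number here means a stronger inhibitor, a higher number a weaker inhibitor), compound 1 gives 9.83 nM. Compound 2, `N[C@]1(C(=O)O)[C@H]2[C@@H](C[C@H]1OCc1cccc(-c3ccccc3)c1)[C@]2(F)C(=O)O`, carries a different ether substituent and in this assay compound 2 gives 9.34 nM. Of the two numbers measured, compound 1 stands highest, with compound 2 as its nearest neighbour, the gap between them lying within the scatter, so no order between compound 1 and compound 2 can be read from them.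

Compound 3, `N[C@]1(C(=O)O)[C@H]2[C@@H](C[C@H]1OCc1ccc(Cl)cc1Cl)[C@]2(F)C(=O)O`, has not been measured in this assay. Against compound 1 the change is 2,4-dichlorophenyl in place of phenethyl on a saturated chain carbon bound to an oxygen on a saturated carbon. Going by the values given here, no step between two measured compounds bears on this change, so the expectation rests only on compound 1 and compound 2, which sit together at the level of compound 1 with 9.83 nM.

The step from compound 1 to compound 3 is expected to be small, a 1.1-fold higher number from compound 1 to compound 3 (0.05 log units; within the scatter), with no direction beyond the scatter favoured. For compound 3 in this assay the estimate is 11 nM, within 3.5 nM to 35 nM.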

Compound 3, inhibition constant: 3.89 nM
Estimate against measurement, compound 3: 2.8-fold (0.45 log units) above; measured number inside the range.
By their numbers in this assay, from the lowest: compound 3; then compounds 2 and 1 (each within the scatter of the next).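

In this assay, the ether substituent on a saturated chain carbon bound to an oxygen on a saturated carbon now shows a readable effect: 2,4-dichlorophenyl in place of phenethyl gives a 2.5-fold lower number from compound 1 to compound 3 (0.40 log units; beyond the scatter) and thus a modest step beyond the scatter, whereas the two earlier ethers gave no order. Both groups have the same count of heavy atoms and one six-membered aromatic ring of carbon only, and neither has a hydrogen-bond donor or acceptor, so these counts do not distinguish them even though the number moves. No measurement available here accounts for the step.

The change replaces phenethyl with 2,4-dichlorophenyl in a single step, leaving open how much of it belongs to the two chlorine atoms and how much to the rest of the group; a plain phenyl or a single chlorine on the ring would bear on this. Also open, from the compounds shown here alone, is how the number responds to a carboxylic acid or an amine on the aromatic ring, or to a longer chain carrying the 2,4-dichlorophenyl group.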